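Replacing the 4-methoxyphenyl with an arylamino group

The source may hold more compounds than are shown below. What is called first, only, known or untested is meant among the compounds shown, and "the series" means these compounds.

Compound 1 `COc1ccc(C(=O)Nc2nn(-c3ccccc3)c(=O)c3ccccc23)cc1`: 0%
Compound 2 `O=C(Nc1ccc(Cl)cc1)Nc1nn(-c2ccccc2)c(=O)c2ccccc12`: 10%

In an assay on CHO cells for displacement of a labelled ligand from adenosine receptor A1 (Homo sapiens), tested at 10 uM (a lower number here means less inhibition, a higher number more inhibition at the concentration tested (going by the name of the read-out)), compound 1 gives 0%, the lowest of the two numbers; compound 2 gives 10%. For the measured compounds named here, the only measured step is a number 10 percentage points higher from compound 1 to compound 2 (within the scatter). Compound 3 `Cc1ccccc1NC(=O)Nc1nn(-c2ccccc2)c(=O)c2ccccc12` differs from compound 1 in one place: (2-methylphenyl)amino in place of 4-methoxyphenyl on a carbonyl carbon. That step between compound 1 and compound 2 also put an arylamino group in place of the 4-methoxyphenyl on the carbonyl carbon and stayed within the scatter, so for compound 3 no change beyond the scatter is expected in this assay, an expected step of a number 5 percentage points higher from compound 1 to compound 3 (within the scatter). Compound 3 is estimated at 5%, between 0% and 20%.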

Compound 3, a percentage reported as inhibition, at one concentration (the size of the read-out at that concentration, not a potency): 20%
For compound 3 the middle estimate is 15 percentage points below the measured one; the range from low to high includes it.
By their numbers in this assay, from the lowest: compounds 1, 2 and 3 (each within the scatter of the next, the first and the last beyond it).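

In this assay, an arylamino group on the carbonyl carbon now gives a step beyond the scatter, a number 20 percentage points higher from compound 1 to compound 3 (beyond the scatter), though a modest one. Exchanging one aryl group for another on the amide-type nitrogen, 2-methylphenyl for 4-chlorophenyl, gives a number 10 percentage points higher from compound 2 to compound 3 (within the scatter), so these two groups cannot be told apart here. No measured evidence bears on why the number changes. The compounds shown leave open whether the aryl ring is needed at all. A cyclohexylamino or benzylamino group on the same carbonyl carbon would test this.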